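The source may hold more compounds than are shown below. What is called first, only, known or untested is meant among the compounds shown, and "the series" means these compounds.

Measured in a functional assay on SW480 cells (Homo sapiens) for antiproliferative activity, with a stated time of 72 h; on this read-out lower numbers stand for stronger inhibition and higher numbers for weaker inhibition:
- compound 1 `O=C(COc1ccc(CN2CC=C(c3c[nH]c4cccc(F)c34)CC2)c(F)c1)NO`: 5560 nM
- compound 2 `O=C(COc1ccc(CNC2CC=C(c3c[nH]c4cccc(F)c34)CC2)c(F)c1)NO`: 189 nM
- compound 3 `O=C(COc1ccc(CNC2CC=C(c3c[nH]c4ccc(F)cc34)CC2)c(F)c1)NO`: 179 nM

Compound 3 shares the low end of these numbers with one neighbour. The measured step is a 1.1-fold lower number from compound 2 to compound 3 (0.02 log units; within the scatter), so those two values cannot be told apart. Compound 1, at 5560 nM, stands well above compound 3, at 179 nM.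

The next compound is compound 4 `Cc1ccc2[nH]cc(C3=CCC(NCc4ccc(OCC(=O)NO)cc4F)CC3)c2c1`, which turns 5-fluoro-1H-indol-3-yl into 5-methyl-1H-indol-3-yl: methyl in place of fluoro on an aromatic carbon. In words, this is methyl in place of fluoro on an aromatic carbon.

Among the measured compounds shown here, no measured step makes this exact swap, so the evidence is indirect. For the measured compounds named here, only one step touches the same group: moving the fluoro, with 5-fluoro-1H-indol-3-yl in place of 4-fluoro-1H-indol-3-yl, gave a 1.1-fold lower number from compound 2 to compound 3 (0.02 log units; within the scatter). That result suggests the number in this assay may tolerate a small change here, but a shifted fluoro is not a methyl. Compound 1 and compound 2 carry the same 4-fluoro-1H-indol-3-yl group, so their gap says nothing about this change.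

No shift beyond the scatter is therefore expected, in either direction, and the expected step is a 1.1-fold higher number from compound 3 to compound 4 (0.05 log units; within the scatter). For compound 4 the estimated value is 200 nM, with an expected range from 90 nM to 450 nM.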

Compound 4, half-maximal inhibitory concentration: 2780 nM
The estimate for compound 4 lay 14-fold (1.14 log units) below the measured number, and the stated range ends below it.
By their numbers in this assay, from the lowest: compounds 3 and 2 (each within the scatter of the next); then compounds 4 and 1 (each within the scatter of the next).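

In this assay, exchanging fluoro for methyl on an aromatic carbon of the six-membered aromatic ring gives a 16-fold higher number from compound 3 to compound 4 (1.19 log units; beyond the scatter), so the number is sensitive to which group sits at this spot, even though only one heavy atom leaves and one enters. The earlier step, a 1.1-fold lower number from compound 2 to compound 3 (0.02 log units; within the scatter), involved only a moved fluoro, so the tolerance it showed covers that move and does not extend to other groups. The comparison with the other fluoro compound points the same way, with a 15-fold higher number from compound 2 to compound 4 (1.17 log units; beyond the scatter), which sets the 5-methyl-1H-indol-3-yl compound clearly apart from both the 4-fluoro and the 5-fluoro compounds.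

Nothing available here explains why this single exchange changes the number so much. As far as these compounds go, it also remains open whether fluoro is special at this spot or methyl is unusually poor there, a question that the plain 1H-indol-3-yl group, or a chloro, methoxy or nitrile group at the same carbon, or the isomeric 4-methyl-1H-indol-3-yl group, could help to settle.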